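Dechlorination of the bicyclic core: expected clearance in mouse microsomes

The source may report more compounds than this note shows. Statements on the series, on what has been measured and on what is new or still open speak of the compounds shown alone.

Compound 1 `CC1CCC(NC(=O)c2cc3c(Cl)cc(Cl)cc3[nH]2)CC1` and compound 2 `C[C@H]1CC[C@@H](NC(=O)c2cc3c(Cl)cc(Cl)cc3[nH]2)CC1` share one set of atoms and bonds. In an ADME assay on microsomes from liver (Mus musculus) for metabolic stability, read by LC-MS (a lower number here means slower removal, a higher number faster removal of the compound), compound 1 gives 37 mL.min-1.g-1, and compound 2 gives 47 mL.min-1.g-1. Among the compounds with values here, the only step measured so far, a 1.3-fold higher number from compound 1 to compound 2 (0.10 log units; within the scatter), concerns the fact that one of compounds 1 and 2 is drawn with a defined configuration and the other without, at the place where they differ and nothing else. Compound 1 holds the lowest of the two numbers, its nearest neighbour being compound 2 within the scatter.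

Compound 3 `CC1CCC(NC(=O)c2cc3ccc(Cl)cc3[nH]2)CC1` departs from compound 1 by hydrogen in place of chloro on an aromatic carbon. Within the data shown here, no measured step changes a substituent on the shared core; the one step available, from compound 1 to compound 2, left the clearance within the scatter, so it offers no guidance on a chloro removal. The expectation for this assay is therefore a step of about a 1.2-fold higher number from compound 1 to compound 3 (0.09 log units; within the scatter), with no direction beyond the scatter claimed. Compound 3 is estimated at 45 mL.min-1.g-1, within a range of 18 mL.min-1.g-1 to 110 mL.min-1.g-1.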

Compound 3, intrinsic clearance in microsomes: 433 mL.min-1.g-1
For compound 3 the middle estimate is 9.6-fold (0.98 log units) below the measured one; the measured number lies above the stated range.
By their numbers in this assay, from the lowest: compounds 1 and 2 (each within the scatter of the next); then compound 3.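

In this assay, within the data shown here, hydrogen in place of chloro on the aromatic carbon ortho to a fused ring gives a 12-fold higher number from compound 1 to compound 3 (1.07 log units; beyond the scatter), and this is the first step that lies beyond the scatter. Among these compounds, the clearance therefore depends strongly on this position of the shared core, whereas the only earlier step, a 1.3-fold higher number from compound 1 to compound 2 (0.10 log units; within the scatter), concerned drawn configuration and stayed within the scatter. No measurement at hand bears on why this chloro removal has so large a step.

On these data alone, it remains open whether any group at this position would hold the clearance near the level of compound 1, or whether that is particular to chloro; a fluoro, a methyl or a nitrile there would separate the two cases. Also open, as far as these compounds go, is whether removing the other chloro group, which stands meta to this position, gives a step of similar size.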